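This account rests on a few compounds, and the source may have more. Where it says the series, first, only, none or still open, it means among the compounds named here.

Series of three measured analogues on a shared core. Compound 1 `CCC(O)CSc1nc(NCc2ccc(-c3ccccn3)cc2)c2[nH]nc(C(C)C)c2n1` gives 273 nM in a functional assay on HT cells (Homo sapiens) for antiproliferative activity, read by fluorescence, with a stated time of 72 h; a lower number here means a stronger inhibitor of growth, a higher number a weaker inhibitor of growth; compound 2 `C=CCSc1nc(NCc2ccc(-c3ccccn3)cc2)c2[nH]nc(C(C)C)c2n1` gives 1010 nM; compound 3 `CC(C)c1n[nH]c2c(NCc3ccc(-c4ccccn4)cc3)nc(SCC(O)CN3CCNCC3)nc12` gives 332 nM, second highest of the three, within the scatter of compound 1 and beyond it only against compound 2 (a 3.0-fold lower number from compound 2 to compound 3 (0.48 log units; beyond the scatter)).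

Compound 4 `CSCCSc1nc(NCc2ccc(-c3ccccn3)cc2)c2[nH]nc(C(C)C)c2n1` is not yet measured. Change from compound 3: (methylsulfanyl)methyl in place of 1-hydroxy-2-(piperazin-1-yl)ethyl on a saturated chain carbon bound to a sulfur. Bearing on it: a 1.2-fold higher number from compound 1 to compound 3 (0.08 log units; within the scatter) shows the piperazin-1-yl adding little, while a 3.7-fold higher number from compound 1 to compound 2 (0.57 log units; beyond the scatter) shows that a short chain lacking the hydroxyl raises the number modestly. A modest rise is therefore expected, a 2.1-fold higher number from compound 3 to compound 4 (0.32 log units; beyond the scatter).

Compound 4 is expected at 700 nM, range 300 nM to 1800 nM.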

Compound 4, concentration for 50% growth inhibition: 975 nM
Compound 4: the middle estimate sits 1.4-fold (0.14 log units) below what was measured; the measured number falls inside the stated range.
By their numbers in this assay, from the lowest: compounds 1 and 3 (each within the scatter of the next); then compounds 4 and 2 (each within the scatter of the next).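

In this assay, (methylsulfanyl)methyl in place of vinyl on a saturated chain carbon bound to a sulfur leaves the number within the scatter (a 1.0-fold lower number from compound 2 to compound 4 (0.02 log units; within the scatter)), so this thioether chain and the vinyl chain of compound 2 cannot be told apart. Both hydroxyl-bearing chains give lower numbers (a 2.9-fold higher number from compound 3 to compound 4 (0.47 log units; beyond the scatter); a 3.6-fold higher number from compound 1 to compound 4 (0.55 log units; beyond the scatter)), and no compound shown goes against this split. No measurement shown gives a reason for it.

On these data alone, whether the hydroxyl alone carries these steps stays open. A 2-(piperazin-1-yl)ethyl chain or a 2-hydroxyethyl chain at this position would separate the hydroxyl from the rest of the chain.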